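The source may hold more compounds than are shown below. What is called first, only, known or untested is meant among the compounds shown, and "the series" means these compounds.

Measured compounds:
compound 1 `COc1ccc(N)cc1-c1cnc2[nH]cc(-c3ccncc3)c2c1`, value 110 nM
compound 2 `CC(=O)Nc1cc(N)cc(-c2cnc3[nH]cc(-c4ccncc4)c3c2)c1`, value 5.41 nM

In an assay on isolated protein for inhibition of high affinity nerve growth factor receptor (Homo sapiens), read by 33P incorporation (on this read-out higher numbers stand for weaker inhibition and lower numbers for stronger inhibition), compound 2 stands lowest of the two numbers; compound 1 gives the higher number, and that gap is beyond the scatter. Compound 3 `Nc1cccc(-c2cnc3[nH]cc(-c4ccncc4)c3c2)c1` differs from compound 2 by hydrogen in place of acetamido on an aromatic carbon. Going by the values given here, no step between measured compounds isolates this change, so the expectation rests on the two values alone. Removing the acetamido from compound 2 is expected to raise the number, with an expected step of a 5.5-fold higher number from compound 2 to compound 3 (0.74 log units; beyond the scatter) beyond the scatter. For compound 3 the estimate is 30 nM, with a range from 8 nM to 120 nM.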

Compound 3, half-maximal inhibitory concentration: 42.7 nM
Compound 3: middle estimate off by 1.4-fold (0.15 log units), on the low side, and the stated range covers the measured number.
By their numbers in this assay, from the lowest: compound 2; then compound 3; then compound 1.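

In this assay the acetamido counts for much of the low number of compound 2, since removing it gives a 7.9-fold higher number from compound 2 to compound 3 (0.90 log units; beyond the scatter). Substitution on this ring does not lower the number in itself: hydrogen in place of methoxy gives a 2.6-fold lower number from compound 1 to compound 3 (0.41 log units; beyond the scatter), so compound 1 goes against any such reading. Nothing here gives a measured cause for either step.

Open, from the compounds shown here alone, is whether the gain needs the whole acetamido: a methyl group, a methanesulfonamide or a longer acyl chain on the same carbon would separate the carbonyl from the amide hydrogen.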